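The compounds below may be only part of what the source reports. "The series", "measured", "known", "first", "only" and "open" are said of these compounds alone.

Measured compounds:
- compound 1, `Nc1nn(C(=O)Nc2ccc(Cc3ccccc3)cc2)c2ccccc12`, gives 2900 nM in a functional assay on NCI-H522 cells (Homo sapiens) for antiproliferative activity, read by sulforhodamine B assay, with a stated time of 48 h; a lower number here means a stronger inhibitor of growth, a higher number a weaker inhibitor of growth
- compound 2, `Nc1nn(C(=O)Nc2ccc(Cc3ccccc3)cc2)c2ccc(Cl)cc12`, gives 15600 nM

Compound 2 stands at the highest of these two numbers; its nearest neighbour is compound 1, and the step between them was a 5.4-fold higher number from compound 1 to compound 2 (0.73 log units; beyond the scatter). Compound 3, `Nc1ccc2c(c1)c(N)nn2C(=O)Nc1ccc(Cc2ccccc2)cc1`, has not yet been measured. It differs from compound 2 by amino in place of chloro on an aromatic carbon. Going by the values given here, only one measured step touches this position: a 5.4-fold higher number from compound 1 to compound 2 (0.73 log units; beyond the scatter), in which chloro replaced hydrogen and the number rose. Among the compounds with values here, removing the chloro again could return the number toward that of compound 1, but no measured compound carries an amino group at this place, so the contribution of the amino itself is unknown. The expectation is therefore a modest step down: a 3.1-fold lower number from compound 2 to compound 3 (0.49 log units; beyond the scatter). For compound 3 the estimate in this assay is 5000 nM, with a range from 1500 nM to 20000 nM.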

Compound 3, concentration for 50% growth inhibition: 14700 nM
Compound 3: the middle estimate sits 2.9-fold (0.47 log units) below what was measured; measured number inside the range.
By their numbers in this assay, from the lowest: compound 1; then compounds 3 and 2 (each within the scatter of the next).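

In this assay, amino in place of chloro on this aromatic carbon gives a result that stays within the scatter (a 1.1-fold lower number from compound 2 to compound 3 (0.03 log units; within the scatter)), even though amino brings a hydrogen-bond donor and acceptor and chloro brings neither. Measured against hydrogen at the same place, amino gives a clear step (a 5.1-fold higher number from compound 1 to compound 3 (0.70 log units; beyond the scatter)), so the weaker growth inhibition seen with chloro is no longer a finding about one group: both substituents tested here give higher numbers than compound 1. No measurement at hand explains this result.

On these data alone, whether a fluoro, methyl or methoxy group at this place would give the same higher number, or stay close to compound 1, remains open. As far as these compounds go, it is also open whether any group here can give a lower number than hydrogen.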